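The compounds below may be only part of what the source reports. "The series", "measured", "known", "first", "only" and "open" are said of these compounds alone.

Measured in a functional assay on HeLa cells (Homo sapiens); a lower number here means that less compound is needed, a higher number that more compound is needed for the effect:

Compound 1 `CCOC(=O)c1cc(CCl)nn1C1O[C@H](COC(C)=O)[C@@H](OC(C)=O)[C@H](OC(C)=O)[C@H]1OC(C)=O`: > 100 ug/mL, a limit of the assay and not a number
Compound 2 `CC(=O)OC[C@H]1O[C@@H](n2nc(CCl)cc2C(N)=O)[C@H](OC(C)=O)[C@@H]1OC(C)=O`: 26 ug/mL
Compound 3 `CC(=O)OC[C@H]1O[C@@H](n2nc(C(N)=O)cc2CCl)[C@H](OC(C)=O)[C@@H]1OC(C)=O`: 12 ug/mL

Only two of these results are actual numbers. Compound 3 has the lower one, 12 ug/mL, so less of it is needed for the effect. Compound 2 gives 26 ug/mL, and the gap between the two lies beyond the usual scatter of repeated measurements.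

Compound 4 `CC(=O)OC[C@H]1O[C@@H](n2nc(C(N)=O)cc2CI)[C@H](OC(C)=O)[C@@H]1OC(C)=O` is the next compound to follow. It keeps everything in compound 3 except for a single atom: iodo in place of chloro on a saturated chain carbon bound to an aromatic carbon. This puts iodo in place of chloro on a saturated chain carbon bound to an aromatic carbon, turning chloromethyl into iodomethyl.

No measured pair among these compounds differs in one place only, so the data do not show directly what this swap does in this assay. The expectation therefore starts from compound 3 at 12 ug/mL and allows for movement either way. The expected step is a 1.5-fold lower number from compound 3 to compound 4 (0.18 log units; within the scatter), leaning towards a lower number but staying within the scatter. For compound 4 the estimate is 8 ug/mL, with an expected range from 3 ug/mL to 25 ug/mL.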

Compound 4, concentration for half-maximal effect: 2 ug/mL
The estimate for compound 4 lay 4.0-fold (0.60 log units) above the measured number; the whole stated range lies above it.
By their numbers in this assay, from the lowest: compound 4; then compound 3; then compound 2. At a limit, above all of these: compound 1.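

Until this result, no two compounds shown differed in one place only, so nothing could be said about any single change. In this assay, putting iodo in place of chloro on a saturated chain carbon bound to an aromatic carbon gives a 6.0-fold lower number from compound 3 to compound 4 (0.78 log units; beyond the scatter), which shows that the outcome at this place depends on which halogen is attached, even though the swap involves no ring, no hydrogen-bond donor or acceptor and no net charge. The data shown give no measured property that would explain why this swap has this effect.

Which other groups this place would accept remains open: bromomethyl, hydroxymethyl or aminomethyl could each follow the chloromethyl-to-iodomethyl step or depart from it. On these data alone, it is also open whether iodomethyl would bring a similar step on the arrangement in compound 2, since this single pair in a single assay sets no general rule.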